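From compound 2 to compound 4: a ring hydroxy

The source may hold more compounds than are shown below. What is called first, only, known or untested is meant among the compounds shown, and "the series" means these compounds.

In a functional assay on NP14 cells (Homo sapiens) for cytotoxicity, read by MTT assay, with a stated time of 48 h (a higher number here means a weaker inhibitor, a lower number a stronger inhibitor), compound 1 (`C=C1CC[C@@H]2[C@](C)(CO)[C@H](O)CC[C@@]2(C)[C@@H]1CCc1ccoc1`) gives 53300 nM and compound 2 (`C=C1CC[C@@H]2[C@](C)(COC(=O)CC)[C@H](OC(=O)CC)CC[C@@]2(C)[C@@H]1CCc1ccoc1`) gives 94200 nM so these two sit level within the scatter. Compound 3 (`C=C1CC[C@@H]2[C@](C)(COC(=O)C(Cl)Cl)[C@H](OC(=O)C(Cl)Cl)CC[C@@]2(C)[C@@H]1CCc1ccoc1`) gives 4430 nM in this assay and stands well beyond the scatter from compound 2. Compound 4 (`C=C1[C@H](O)C[C@@H]2[C@](C)(COC(=O)CC)[C@H](OC(=O)CC)CC[C@@]2(C)[C@@H]1CCc1ccoc1`) departs from compound 2 by hydroxy in place of hydrogen on a saturated ring carbon with hydroxy in place of hydrogen on a saturated ring carbon. Within the data shown here, no measured pair tests this change, so compound 2 at 94200 nM is the anchor and no shift beyond the scatter is expected. The estimate means a 1.4-fold lower number from compound 2 to compound 4 (0.16 log units; within the scatter) as an expected step, slightly toward a lower number. Compound 4 is estimated at 65000 nM with an expected range from 22000 nM to 170000 nM in this series.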

Compound 4, half-maximal inhibitory concentration: 27700 nM
The estimate for compound 4 lay 2.3-fold (0.37 log units) above the measured number; the measured number falls inside the stated range.
By their numbers in this assay, from the lowest: compound 3; then compounds 4, 1 and 2 (each within the scatter of the next, the first and the last beyond it).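

In this assay, hydroxy in place of hydrogen on a saturated ring carbon, two ring bonds from the ring atom that bears a 2-(furan-3-yl)ethyl group, gives a 3.4-fold lower number from compound 2 to compound 4 (0.53 log units; beyond the scatter), a modest step. The earlier compounds shown here differ only in the groups on the two oxygens, so this ring position is a second place where the number moves. No data on hand explain the step.

From the compounds shown here alone, whether a methoxy group or an acetate ester at this ring carbon acts like hydroxy remains open. So does whether hydroxy here lowers the number with the dichloroacetyl esters of compound 3.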